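Toxicity of a pyrazole urea series on glioma cells

This account rests on a few compounds, and the source may have more. Where it says the series, first, only, none or still open, it means among the compounds named here.

The measured compounds:
Compound 1, `O=C(Nc1cccc(-n2cc(-c3ccncc3)c(-c3ccc(Cl)c(O)c3)n2)c1)Nc1ccc(Cl)c(Cl)c1`: > 32500 nM
Compound 2, `COc1cc(-c2nn(-c3cccc(NC(=O)c4cccc(C(F)(F)F)c4)c3)cc2-c2ccncc2)ccc1Cl`: > 50000 nM
Compound 3, `O=C(Nc1cccc(-n2cc(-c3ccncc3)c(-c3ccc(Cl)c(O)c3)n2)c1)Nc1cc(C(F)(F)F)cc(C(F)(F)F)c1`: 20500 nM

All three share a core and were tested in a functional assay on SF-268 cells (Homo sapiens) for inhibition, read by sulforhodamine B assay, with a stated time of 48 h; on this read-out higher numbers stand for lower toxicity in this test and lower numbers for higher toxicity in this test. Compound 1 gives > 32500 nM, which is a limit of the assay and not a number. Compound 3 differs from compound 1 only in the aryl group on the urea, and compound 3 gives 20500 nM. Compound 2 gives > 50000 nM in this assay, again a limit rather than a number. So compound 2 stands at the least toxic end of what is shown, alongside compound 1, with only compound 3 giving a real value, and that one at the low-toxicity end of the scale as well.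

Compound 4, `COc1cc(-c2nn(-c3cccc(NC(=O)Nc4ccc(Cl)c(C(F)(F)F)c4)c3)cc2-c2ccncc2)ccc1Cl`, is compound 2 with one change: (4-chloro-3-(trifluoromethyl)phenyl)amino in place of 3-(trifluoromethyl)phenyl on a carbonyl carbon. This turns the amide of compound 2 into a urea like those of compound 1 and compound 3. Going by the values given here, since no step between measured compounds is given, the expectation rests on how compound 1 and compound 3 behave. Their values sit at or near the limit, so compound 4 is expected to remain low in toxicity, with the step of an at least 1.4-fold lower number from compound 2 to compound 4 (0.15 log units; that floor lies within the scatter) expected to be small, likely within the scatter. Compound 4 is therefore estimated at 35000 nM, in the range 15000 nM to 80000 nM.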

Compound 4, concentration lethal to 50% of the cells: > 32500 nM
Compound 4: a limit, no number (the forecaster's own chance of this, stated with the estimate: 60%); the middle value does not contradict the limit.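

Compound 2 and compound 4 each carry a limit of the assay and not a number, and the step between them cannot be read. The compounds shown leave open how toxic compound 1, compound 2 and compound 4 actually are to these cells, and whether the urea of compound 4 in place of the amide of compound 2 changes that at all.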